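This account rests on a few compounds, and the source may have more. Where it says the series, first, only, none or still open, it means among the compounds named here.

Measured so far:
compound 1, `Cc1ccccc1Nc1nc(Nc2ccc(N3CCN(C)CC3)cn2)ncc1Cl`: 5210 nM
compound 2, `CCN1CCN(c2ccc(Nc3ncc(Cl)c(Nc4ccccc4C)n3)nc2)CC1`: > 100000 nM

For the measured compounds named here, compound 1, `Cc1ccccc1Nc1nc(Nc2ccc(N3CCN(C)CC3)cn2)ncc1Cl`, carries the only number in a functional assay on MCF7 cells (Homo sapiens) for inhibition, read by CCK-8 assay, with a stated time of 48 h; on this read-out lower numbers stand for stronger inhibition of growth and higher numbers for weaker inhibition of growth; compound 1 gives 5210 nM there. For compound 2, `CCN1CCN(c2ccc(Nc3ncc(Cl)c(Nc4ccccc4C)n3)nc2)CC1`, this assay reports a limit and not a number, > 100000 nM. Going by the values given here, the one measured step, an at least 19-fold higher number from compound 1 to compound 2 (1.28 log units; beyond the scatter), is methyl in place of hydrogen on a saturated chain carbon bound to an amine nitrogen in a ring, and it runs out to the limit of > 100000 nM in this assay, at which 1 of the 2 values shown sits.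

Compound 3, `COc1ccc(Nc2nc(Nc3ccc(N4CCN(C)CC4)cn3)ncc2Cl)cc1`, differs from compound 1 by 4-methoxyphenyl in place of 2-methylphenyl on a nitrogen on an aromatic ring. Among the compounds with values here, the change sits on the other nitrogen of the shared core than the measured step, so that step tells nothing directly about it, and no other step touches this part. With nothing to lean on, the expectation is that compound 3 stays near compound 1: the estimated step is a 1.2-fold higher number from compound 1 to compound 3 (0.06 log units; within the scatter), none beyond the scatter, with a wide range on either side. Compound 3 is thus expected at 6000 nM, between 1500 nM and 30000 nM in this assay.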

Compound 3, concentration for 50% growth inhibition: 8450 nM
Estimate against measurement, compound 3: 1.4-fold (0.15 log units) below; the measured number falls inside the stated range.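

At this position, the first exchange shown leaves the read-out within the scatter in this assay: a 1.6-fold higher number from compound 1 to compound 3 (0.21 log units; within the scatter). The nitrogen on the aromatic ring therefore carries either 2-methylphenyl or 4-methoxyphenyl without a separable difference in growth inhibition, even though the entering group adds an oxygen and a hydrogen-bond acceptor, so compound 1 and compound 3 cannot be ranked against each other. Compound 3 gives a measured number, and compound 2 remains the only compound with a limit and not a number: the limit of > 100000 nM in this assay, at which 1 of the 3 values shown sits.

One step cannot separate the group from its place on the ring, as 2-methylphenyl and 4-methoxyphenyl differ in both, and it covers only these two substituted phenyl rings. The compounds shown leave open whether an amine or a carboxylic acid on this phenyl ring would move the value beyond the scatter, and whether the large loss seen with the ethyl group on the other side of the shared core would also appear alongside 4-methoxyphenyl.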